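The source may report more compounds than this note shows. Statements on the series, on what has been measured and on what is new or still open speak of the compounds shown alone.

The study measures an in vitro ADME assay on microsomes (Homo sapiens) for metabolic stability (on this read-out lower numbers stand for a shorter-lived compound and higher numbers for a longer-lived compound), on compounds built around one shared core. Compound 1 `CCC(CC)Nc1nc(OC)c(-c2ccc(Cl)cc2Cl)nc1OC` gives 0.267 h in this assay. Compound 2 `CCc1nc(-c2ccc(Cl)cc2Cl)c(CC)nc1SC(C)CC` gives 0.283 h in this assay, and this value stands level with that of compound 1, the two lying within the scatter of each other, so no order between them can be read from the numbers. Compound 3 `CCc1nc(-c2ccc(Cl)cc2Cl)c(CC)nc1CC(CC)CC` has not yet been measured in this assay. It differs from compound 2 in one place: 2-ethylbutyl in place of (sec-butyl)sulfanyl on an aromatic carbon. Within the data shown here, no step between two measured compounds shows what such a change does here, and the two measured values give no trend to lean on. The step from compound 2 to compound 3 is therefore expected to stay within the scatter, with a 1.1-fold higher number from compound 2 to compound 3 (0.03 log units; within the scatter) as the estimate. For compound 3 a value of 0.3 h is expected, with a range from 0.12 h to 0.8 h.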

Compound 3, half-life: 0.217 h
Estimate against measurement, compound 3: 1.4-fold (0.14 log units) above; low and high end bracket the measured number.
By their numbers in this assay, from the lowest: compounds 3, 1 and 2 (each within the scatter of the next).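

In this assay, among these compounds, the exchange of (sec-butyl)sulfanyl for 2-ethylbutyl gives a 1.3-fold lower number from compound 2 to compound 3 (0.12 log units; within the scatter) and is the only single-place step that can be read in this set. On this aromatic carbon next to the ring nitrogen, a chain joined through sulfur can therefore give way to an all-carbon chain without the half-life leaving the scatter. Nothing shown here gives a reason for this result.

The compounds shown leave open whether a morpholine ring or a carboxylic acid on this carbon would shift the half-life beyond the scatter. They also leave open whether the same exchange would give a similar result with methoxy groups in place of the two ethyl groups on the shared core.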